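The source may hold more compounds than are shown below. What is called first, only, known or untested is meant among the compounds shown, and "the series" means these compounds.

Compound 1 `CCCCCCCCCCn1cc(Cn2c(C)nc3nc(-c4ccccc4)cc(C(F)(F)F)c3c2=O)nn1` was tested in a functional assay on THP-1 cells (Homo sapiens) for cytotoxicity, read by MTT assay, with a stated time of 24 h (on this read-out higher numbers stand for weaker inhibition and lower numbers for stronger inhibition), and gave 11.3 ug/mL. Compound 3 `CCCCCCCCCCn1cc(Cn2c(CC)nc3nc(-c4ccccc4)cc(C(F)(F)F)c3c2=O)nn1` is the partner of compound 1 that carries methyl in place of hydrogen on a saturated chain carbon bound to an aromatic carbon, and in this assay compound 3 gives 82.7 ug/mL. That single addition produced a 7.3-fold higher number from compound 1 to compound 3 (0.86 log units; beyond the scatter), a weakening of the cytotoxic effect that lies outside the usual scatter. Compound 2 `CCc1nc2nc(-c3ccccc3)cc(C(F)(F)F)c2c(=O)n1Cc1cn(CCC(F)(F)C(F)(F)C(F)(F)C(F)(F)C(F)(F)C(F)(F)C(F)(F)C(F)(F)F)nn1` rests on a different core, and the difference between the two cores is not broken down here. In this assay compound 2 reached only a limit, > 200 ug/mL. That value sits at the limit of > 200 ug/mL in this assay, at which 1 of the 3 values shown sits, so no number for compound 2 is known.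

Compound 4 `CC(C)c1nc2nc(-c3ccccc3)cc(C(F)(F)F)c2c(=O)n1Cc1cn(CCC(F)(F)C(F)(F)C(F)(F)C(F)(F)C(F)(F)C(F)(F)C(F)(F)C(F)(F)F)nn1` has not yet been measured; it differs from compound 2 by methyl in place of hydrogen on a saturated chain carbon bound to an aromatic carbon and a saturated chain carbon. The place is not word for word the same as in the first pair: in compound 1 the carbon is bound to an aromatic carbon, whereas in compound 2 it is bound to an aromatic carbon and a saturated chain carbon, so the change from compound 2 to compound 4 is the same kind of change as that from compound 1 to compound 3, not the same. Among the measured compounds shown here, since the one measured example of this kind of change weakened inhibition, and compound 2 already stands at the limit, the expected step is a step that the limit leaves unreadable from compound 2 to compound 4. The estimate for compound 4 in this assay is therefore 300 ug/mL, with a range from 150 ug/mL to 800 ug/mL, and the result is most likely to be reported again only as a limit.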

Compound 4, half-maximal inhibitory concentration: 142 ug/mL
Compound 4: the middle estimate sits 2.1-fold (0.32 log units) above what was measured; the measured number lies below the stated range.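

In this assay the new pair gives an at least 1.4-fold lower number from compound 2 to compound 4 (0.14 log units; that floor lies within the scatter), which does not repeat the rise in the number seen in the first pair. Set beside the earlier step, this shows that the same methyl-for-hydrogen change did not carry over with the same size from the core of compound 1 to the core of compound 2: the same change on two cores in this assay, a 7.3-fold higher number (0.86 log units; beyond the scatter) from compound 1 to compound 3 and an at least 1.4-fold lower number (0.14 log units; that floor lies within the scatter) from compound 2 to compound 4, at least 10-fold (1.01 log units) apart, beyond the scatter of two such steps

Compound 2 is known only as a limit of the assay, > 200 ug/mL, so the full size of the new step stays unknown, and two pairs cannot show which structural difference between the cores sets the gap or whether the gap would hold for other pairs.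

The compounds shown leave open how an isopropyl group on the core of compound 1 would read, which would place the ethyl to isopropyl change on that core as well. They also leave open how a propyl chain or a cyclopropyl group in that same place would read on either core, and so whether the number follows any steady course as this group grows.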